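Taking the Bromine Off Compound 2

A few compounds are considered here, and "the series" means these few. Any claim that something is new, unique, unknown or untested is made for them only; others in the source may bear on it.

Three measured compounds share one core and differ only in the aryl group on the exocyclic double bond. Compound 1 `O=C1C(=Cc2ccc(O)cc2)C(=O)N(c2ccc(Cl)cc2)N1c1ccc(Cl)cc1` gives 23200 nM in a functional assay on MCF7 cells (Homo sapiens) for cytotoxicity, read by MTT assay, with a stated time of 72 h; on this read-out higher numbers stand for weaker inhibition and lower numbers for stronger inhibition. Compound 2 `O=C1C(=Cc2ccc(Br)cc2)C(=O)N(c2ccc(Cl)cc2)N1c1ccc(Cl)cc1` gives 30400 nM in this assay, and compound 3 `COc1cccc(C=C2C(=O)N(c3ccc(Cl)cc3)N(c3ccc(Cl)cc3)C2=O)c1OC` gives 11900 nM. Among the measured compounds shown here, compound 2 has the highest number of the three, but the step of a 1.3-fold higher number from compound 1 to compound 2 (0.12 log units; within the scatter) lies within the scatter, so compound 2 and compound 1 cannot be placed in order; only the step of a 2.6-fold lower number from compound 2 to compound 3 (0.41 log units; beyond the scatter) is beyond it.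

Compound 4 `O=C1C(=Cc2ccccc2)C(=O)N(c2ccc(Cl)cc2)N1c1ccc(Cl)cc1` differs from compound 2 in one place: hydrogen in place of bromo on an aromatic carbon. The step that bears most on this is a 1.3-fold higher number from compound 1 to compound 2 (0.12 log units; within the scatter), where one group replaced another on the same aromatic carbon of compound 1 and the number hardly moved. The step of a 1.9-fold lower number from compound 1 to compound 3 (0.29 log units; within the scatter) was also within the scatter, and only the exchange of the whole aryl ring in a 2.6-fold lower number from compound 2 to compound 3 (0.41 log units; beyond the scatter) went beyond it. Swapping a single substituent on this ring has so far done little, so no step beyond the scatter is expected in this assay for compound 4, perhaps a slightly lower number. Compound 4 is therefore estimated at 25000 nM, within 12000 nM to 50000 nM, which means an expected step of a 1.2-fold lower number from compound 2 to compound 4 (0.08 log units; within the scatter).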

Compound 4, half-maximal inhibitory concentration: 20200 nM
The estimate for compound 4 lay 1.2-fold (0.09 log units) above the measured number; the measured number falls inside the stated range.
By their numbers in this assay, from the lowest: compounds 3, 4, 1 and 2 (each within the scatter of the next, the first and the last beyond it).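

With the bromo gone and only hydrogen on the aromatic carbon para to a large group, the number in this assay stays within the scatter (a 1.5-fold lower number from compound 2 to compound 4 (0.18 log units; within the scatter)), so this carbon now has a baseline that the earlier exchange of one substituent for another could not provide. Hydrogen in place of hydroxy gives the same reading (a 1.1-fold lower number from compound 1 to compound 4 (0.06 log units; within the scatter)), which means that neither bromo nor hydroxy at this carbon can be told apart from the bare phenyl compound. The phenyl compound also stays within the scatter of the 2,3-dimethoxyphenyl compound (a 1.7-fold higher number from compound 3 to compound 4 (0.23 log units; within the scatter)), so among these four compounds only the pair of compound 2 and compound 3 differs beyond the scatter, while compound 4 cannot be placed apart from any of the other three.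

The compounds shown leave open whether an amine or a carboxylic acid on this same aromatic carbon would move the number beyond the scatter, and whether a single methoxy group would read differently from the 2,3-dimethoxyphenyl group. Nothing available here bears on why these replacements leave the number so little changed.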